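The source may hold more compounds than are shown below. What is called first, only, known or untested is meant among the compounds shown, and "the series" means these compounds.

Of the compounds shown here, two have been measured so far in an assay on HEK293 cells for displacement of a labelled ligand from D(4) dopamine receptor (Homo sapiens); a lower number here means a stronger inhibitor, a higher number a weaker inhibitor. Within the data shown here, compound 1 `CO/N=C(\CCN1CCN(c2ccccn2)CC1)c1ccc(Cl)cc1` is the first, and in this assay compound 1 gives 38.2 nM. Compound 2 `CO/N=C(\c1ccc(Cl)cc1)C(O)CN1CCN(c2ccccn2)CC1` shares most of its structure with compound 1, and in this assay compound 2 gives 113 nM. That is the higher of the two numbers: compound 1 sits a clear step below compound 2, and that gap lies beyond the usual scatter of repeated measurements.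

Compound 3 `CO/N=C(/c1ccc(Cl)cc1)C(O)CN1CCN(c2ccccn2)CC1` is the compound not yet measured. Compared with compound 2, (the two compounds have the same atoms and bonds; at least one stereo element is drawn with a configuration in one of them and without one in the other: 1 of 2 stereo elements differ; a double bond is drawn E in compound 2 and Z in compound 3). Among the measured compounds shown here, no measured pair here differs in exactly this way, so no step of that kind can be quoted from the data. With every atom and bond kept and only the drawn geometry of one double bond changed, the expected movement is modest, and the two measured compounds give no hint of its direction. Compound 3 is therefore expected to give about 140 nM, with a likely range from 40 nM to 500 nM. The expected change corresponds to a step of a 1.2-fold higher number from compound 2 to compound 3 (0.09 log units; within the scatter) in this assay.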

Compound 3, inhibition constant: 150 nM
Estimate against measurement, compound 3: 1.1-fold (0.03 log units) below; measured number inside the range.
By their numbers in this assay, from the lowest: compound 1; then compounds 2 and 3 (each within the scatter of the next).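

In this assay, redrawing the double bond from E to Z leaves compound 2 and compound 3 indistinguishable, with a 1.3-fold higher number from compound 2 to compound 3 (0.12 log units; within the scatter), so these two compounds show no measurable effect of the drawn geometry at this position. The result also gives a second reading of the hydroxy group, since hydroxy in place of hydrogen on the saturated chain carbon comes with a 3.9-fold higher number from compound 1 to compound 3 (0.59 log units; beyond the scatter), a gap that stays beyond the scatter and leaves compound 1 with the lowest number of the three. The comparison of compound 2 and compound 3 still needs one caution, as it may not be a clean match of two fully defined forms: the fact that one of compounds 2 and 3 is drawn with a defined configuration and the other without, at the place where they differ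

The compounds shown leave open whether an amine or a methoxy group in place of the hydroxy group would give a number closer to that of compound 1 or further from it. They also leave open whether the E and Z drawings would remain this close with an ethoxy group in place of the methoxy group already on the double-bonded nitrogen.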